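The source may hold more compounds than are shown below. What is called first, only, known or untested is meant among the compounds shown, and "the series" means these compounds.

Compound 1 `COc1cc(C)cc(-c2c(-c3ccnc(-c4ccc(C(C)=O)cc4)c3)cnn2CC#N)c1` gives in a functional assay on UACC-62 cells (Homo sapiens) for inhibition, read by sulforhodamine B assay, with a stated time of 48 h (on this read-out higher numbers stand for weaker inhibition of growth and lower numbers for stronger inhibition of growth), only a limit, > 100000 nM.
Compound 2 `COc1cc(C)cc(-c2nn(CC#N)cc2-c2ccc(-c3cccc(C(C)=O)c3)nc2)c1` likewise gives in this assay only a limit, > 100000 nM.
Compound 3 `Cc1cc(O)cc(-c2nn(CC#N)cc2-c2ccnc(-c3ccc(Oc4ccccc4)cc3)c2)c1` gives in this assay 18100 nM.

Going by the values given here, compound 3 thus holds the only number in this assay, while the other two compounds sit at the limit of > 100000 nM in this assay, at which 2 of the 3 values shown sit. Compound 4 `Cc1cc(O)cc(-c2nn(CC#N)cc2-c2ccnc(-c3ccc(N(C)C)cc3)c2)c1` is not yet measured; it differs from compound 3 by dimethylamino in place of phenoxy on an aromatic carbon. Among the compounds with values here, no measured pair shows this change, so the account expects a step from compound 3 to compound 4 of a 1.1-fold higher number from compound 3 to compound 4 (0.04 log units; within the scatter), not clearly beyond the usual scatter in either direction. Compound 4 is therefore estimated at 20000 nM in this assay, with a range from 5000 nM to 80000 nM.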

Compound 4, concentration for total growth inhibition: 14000 nM
Compound 4: the middle estimate sits 1.4-fold (0.15 log units) above what was measured; the range from low to high includes it.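

At this place, on an aromatic carbon para to a large group, swapping phenoxy for dimethylamino gives in this assay a 1.3-fold lower number from compound 3 to compound 4 (0.11 log units; within the scatter). Going by these compounds alone, the position therefore accepts a group with no ring in place of one with a six-membered aromatic ring without a step beyond the scatter, which no earlier pair could show. Nothing shown gives a cause for this.

Left open is whether a carboxylic acid, a primary amine or a longer alkyl chain at this place would leave the number equally unchanged.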